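Extending the methoxy group of compound 2

A few compounds are considered here, and "the series" means these few. Any claim that something is new, unique, unknown or untested is made for them only; others in the source may bear on it.

Measured in a functional assay on CHO cells for agonist activity at Free fatty acid receptor 1 (Homo sapiens), read by FLIPR and calcium flux; on this read-out higher numbers stand for an effect only at larger amounts of compound and lower numbers for an effect already at smaller amounts:
compound 1 `Cc1cccc(C)c1-c1cccc(COc2ccc(SCC(=O)O)cc2)c1` gives 195 nM
compound 2 `COc1cc(C)c(-c2cccc(COc3ccc(S(=O)(=O)CC(=O)O)cc3)c2)c(C)c1` gives 57.5 nM
compound 3 `COc1cc(C)c(-c2cccc(COc3ccc4c(c3)SCC4CC(=O)O)c2)c(C)c1` gives 123 nM

Compound 2 stands at the lowest of the three numbers; compound 3 sits at a higher number beyond the scatter, and compound 1 further still, also beyond the scatter. Among the compounds with values here, no two measured compounds differ in only one place, so no single step has been measured in this set.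

Compound 4 `COCCOc1cc(C)c(-c2cccc(COc3ccc(S(=O)(=O)CC(=O)O)cc3)c2)c(C)c1` differs from compound 2 by methoxymethyl in place of hydrogen on a saturated chain carbon bound to an oxygen on an aromatic ring. Within the data shown here, no measured pair tests this change. The step from compound 2 to compound 4 is expected to be a 1.3-fold higher number from compound 2 to compound 4 (0.12 log units; within the scatter), small and not clearly beyond the scatter. Compound 4 is estimated at 75 nM, with a range of 25 nM to 220 nM.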

Compound 4, half-maximal effective concentration: 126 nM
For compound 4 the middle estimate is 1.7-fold (0.23 log units) below the measured one; the range from low to high includes it.
By their numbers in this assay, from the lowest: compound 2; then compounds 3, 4 and 1 (each within the scatter of the next).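

Methoxy to 2-methoxyethoxy gives the first single change read in this series: this assay shows a 2.2-fold higher number from compound 2 to compound 4 (0.34 log units; beyond the scatter) and thus a modest loss at this position. The earlier compounds shown here differ in more than one place, so they could not isolate this position. No evidence available here accounts for the step.

One step cannot separate the effect of chain length from that of the added ether oxygen; a plain propoxy group or a 2-hydroxyethoxy group would bear on that. As far as these compounds go, whether the same change carries over to the core of compound 3 also remains open.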